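A Methyl Group on a Saturated Chain Carbon

The source may hold more compounds than are shown below. What is called first, only, known or untested is meant among the compounds shown, and "the series" means these compounds.

Compound 1 `COc1ccc(Cn2c(C(=O)NCc3ccccc3)cc3sccc32)cc1`: > 100000 nM
Compound 2 `COc1ccc(Cn2c(C(=O)NC(C)c3ccccc3)cc3sccc32)cc1`: > 100000 nM
Compound 3 `COc1ccc(Cn2c(C(=O)N3CCC(C(=O)NCc4ccccc4)CC3)cc3sccc32)cc1`: > 100000 nM

All three values come from an ADME assay on HEK-293T cells (Homo sapiens) for cytotoxicity, read by luminescence, with a stated time of 24 h (on this read-out higher numbers stand for lower toxicity in this test and lower numbers for higher toxicity in this test), and each is a limit of the assay rather than a number. Compound 1 and compound 2 differ in one place: methyl in place of hydrogen on a saturated chain carbon bound to an amide-type nitrogen and an aromatic carbon. The step that the two limits leave unreadable from compound 1 to compound 2 cannot be read in size, because both values sit at the limit (the limit of > 100000 nM in this assay, at which 3 of the 3 values shown sit). Compound 3 has a different core; how the two cores differ is not broken down here. Compound 4 `COc1ccc(Cn2c(C(=O)N3CCC(C(=O)NC(C)c4ccccc4)CC3)cc3sccc32)cc1` is not yet measured in this assay. It relates to compound 3 as compound 2 does to compound 1, by the same change at the same place: methyl in place of hydrogen on a saturated chain carbon bound to an amide-type nitrogen and an aromatic carbon. Since compound 3 already sits at the limit (the limit of > 100000 nM in this assay, at which 3 of the 3 values shown sit), the expected step is a step that the limit leaves unreadable from compound 3 to compound 4. Compound 4 is thus estimated at 150000 nM, most likely again reported only as a limit.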

Compound 4, half-maximal cytotoxic concentration: > 100000 nM
Compound 4: a limit, no number (the forecaster's own chance of this, stated with the estimate: 85%); the middle value is on the limit's open side.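

Compound 3 and compound 4 are both reported only as limits, not numbers, so no step between them can be read: the limit of > 100000 nM in this assay, at which 4 of the 4 values shown sit.

Left open is whether in this assay the methyl group changes anything at all for these compounds.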